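The source may report more compounds than this note shows. Statements on the series, on what has been measured and on what is new or still open speak of the compounds shown alone.

Measured compounds in a functional assay on A549 cells (Homo sapiens) for antiproliferative activity, read by MTT assay, with a stated time of 72 h; on this read-out higher numbers stand for weaker inhibition and lower numbers for stronger inhibition:
- compound 1, `O=C(Nc1ccc(Cl)c(-c2nnc3c(Cl)cccn23)c1)c1ccc(C(F)(F)F)cc1F`: > 100000 nM
- compound 2, `O=C(Nc1ccc(Cl)c(-c2nnc3c(Cl)cccn23)c1)c1cccc(Cl)c1`: 52700 nM
- compound 3, `O=C(Nc1ccc(Cl)c(-c2nnc3c(Cl)cccn23)c1)c1ccc(Cl)cc1Cl`: 61300 nM

The value of compound 1 is a limit of the assay, not a number; it sits at the limit of > 100000 nM in this assay, at which 1 of the 3 values shown sits. Compound 2 stands together with compound 3: the step of a 1.2-fold higher number from compound 2 to compound 3 (0.07 log units; within the scatter) lies within the scatter, so the two numbers cannot be told apart. Compound 4, `CS(=O)(=O)c1cccc(C(=O)Nc2ccc(Cl)c(-c3nnc4c(Cl)cccn34)c2)c1`, differs from compound 2 by methylsulfonyl in place of chloro on an aromatic carbon. Going by the values given here, no measured step exchanges chloro for methylsulfonyl, and the one measured step on the same ring moved nothing beyond the scatter. For compound 4 the expectation is therefore a step of a 1.1-fold higher number from compound 2 to compound 4 (0.06 log units; within the scatter) in this assay, with no direction beyond the scatter. Compound 4 is thus estimated at 60000 nM, within 20000 nM to 180000 nM.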

Compound 4, half-maximal inhibitory concentration: > 100000 nM
Compound 4: a limit, no number (the forecaster's own chance of this, stated with the estimate: 30%); at least 1.6-fold (0.22 log units) between middle value and limit.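

Compound 4 stands at a limit of this assay, not at a number, and shares it with compound 1: the limit of > 100000 nM in this assay, at which 2 of the 4 values shown sit. Chloro to methylsulfonyl on this aromatic carbon is thus the first change at this place whose step has only a floor (an at least 1.8-fold higher number from compound 2 to compound 4 (0.27 log units; that floor lies within the scatter)). The step on the carbonyl side reads the same way (an at least 1.6-fold higher number from compound 3 to compound 4 (0.21 log units; that floor lies within the scatter)), so neither step has a known size and neither floor clears the scatter.

On these data alone, whether an amine or a carboxylic acid on this aromatic carbon would give a number apart from compound 2 stays open.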